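A few compounds are considered here, and "the series" means these few. Any claim that something is new, unique, unknown or untested is made for them only; others in the source may bear on it.

Compound 1 `COc1cccc(OS(=O)(=O)c2ccc(N3CCN(C)C3=O)cc2)c1` and compound 2 `CCN1CCN(c2ccc(S(=O)(=O)Oc3cccc(OC)c3)cc2)C1=O` share one core. In a functional assay on M21 cells (Homo sapiens) for antiproliferative activity, read by sulforhodamine B assay, with a stated time of 48 h (a higher number here means a weaker inhibitor, a lower number a stronger inhibitor), compound 1 gives 1600 nM, while compound 2 gives 7000 nM. The change between them, (methyl in place of hydrogen on a saturated chain carbon bound to an amide-type nitrogen in a ring), produced a 4.4-fold higher number from compound 1 to compound 2 (0.64 log units; beyond the scatter). Compound 3 `CCCN1CCN(c2ccc(S(=O)(=O)Oc3ccccc3C)cc2)C1=O` carries a core whose difference from that of compound 1 is not broken down here. In this assay compound 3 gives only a limit, > 100000 nM, namely (the limit of > 100000 nM in this assay, at which 1 of the 3 values shown sits). Compound 4 `CCCN1CCN(c2ccc(S(=O)(=O)Oc3ccccc3CC)cc2)C1=O` differs from compound 3 by methyl in place of hydrogen on a saturated chain carbon bound to an aromatic carbon; this is the same kind of change as that from compound 1 to compound 2, not the same, since here the place is a saturated chain carbon bound to an aromatic carbon rather than one bound to an amide-type nitrogen in a ring. Because compound 3 already sits at the limit of > 100000 nM in this assay, at which 1 of the 3 values shown sits, the step from compound 3 to compound 4 is expected to be roughly a step that the limit leaves unreadable from compound 3 to compound 4, set beside the earlier one, with the result most likely again a limit. For compound 4 the expected value is 150000 nM, between 40000 nM and 600000 nM.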

Compound 4, half-maximal inhibitory concentration: > 50000 nM
Compound 4 ended at the assay's limit (the forecaster's own chance of this, stated with the estimate: 80%); the middle value does not contradict the limit.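

In this assay compound 3 gives only the limit > 100000 nM as its reading. Going by these compounds alone, compound 4 also gives only a limit, > 50000 nM, so no step between the two can be read. The compounds shown leave open how far 2-methylphenyl and 2-ethylphenyl differ in antiproliferative activity.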